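Adding Chloro to a Fluorobenzyl Sulfone

This account rests on a few compounds, and the source may have more. Where it says the series, first, only, none or still open, it means among the compounds named here.

Compound 1 `CCOC(=O)C1=CCCCC1S(=O)(=O)Cc1ccccc1` gives 101 nM in a functional assay on RAW264.7 cells (Mus musculus), read by fluorescence; a higher number here means a weaker inhibitor, a lower number a stronger inhibitor.
Compound 2 `CCOC(=O)C1=CCCCC1S(=O)(=O)Cc1ccccc1F` gives 97 nM in this assay.
Compound 3 `CCOC(=O)C1=CCCCC1S(=O)(=O)Cc1ccccc1Cl` gives 14 nM; 1200 nM; 11 nM (3 entries) in this assay.

Compound 2 stands lowest of the two single numbers, and the step of a 1.0-fold lower number from compound 1 to compound 2 (0.02 log units; within the scatter) lies within the scatter, so it cannot be called stronger than compound 1. Compound 4 `CCOC(=O)C1=CCCCC1S(=O)(=O)Cc1cccc(Cl)c1F` differs from compound 2 by chloro in place of hydrogen on an aromatic carbon. Within the data shown here, no measured step adds a chloro at this place; the only hint comes from the several entries of compound 3 in this assay, 14 nM; 1200 nM; 11 nM (3 entries), whose three entries spread widely, two low and one high. A moderate drop in this assay is therefore expected, a 1.9-fold lower number from compound 2 to compound 4 (0.29 log units; within the scatter), but with wide uncertainty. The estimate for compound 4 is 50 nM, ranging from 10 nM to 250 nM.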

Compound 4, half-maximal inhibitory concentration: 12 nM
Beside the measured number, compound 4's estimate is 4.2-fold (0.62 log units) above it; the measured number falls inside the stated range.
By their numbers in this assay, from the lowest: compound 4; then compounds 2 and 1 (each within the scatter of the next).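

Chloro in place of hydrogen, ortho to the fluoro group, gives an 8.1-fold lower number from compound 2 to compound 4 (0.91 log units; beyond the scatter) in this assay. This is the first step shown that lies beyond the scatter, unlike the fluoro change, a 1.0-fold lower number from compound 1 to compound 2 (0.02 log units; within the scatter). The number for compound 4 resembles the two low entries of compound 3, but the high entry keeps that comparison loose: the several entries of compound 3 in this assay, 14 nM; 1200 nM; 11 nM (3 entries)

Still open, on these data alone, is whether another group at this place, such as methyl or trifluoromethyl, would give a similarly low number. As far as these compounds go, it is also open whether the ester could give way to a carboxylic acid or an amide.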